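A few compounds are considered here, and "the series" means these few. Any claim that something is new, unique, unknown or untested is made for them only; others in the source may bear on it.

Measured so far in a functional assay on MGC-803 cells (Homo sapiens) for antiproliferative activity, read by MTT assay, with a stated time of 72 h; on this read-out higher numbers stand for weaker inhibition and lower numbers for stronger inhibition:

- compound 1 `Cc1ccccc1-n1nc(-c2ccccc2)nc1CNc1ccc(C(=O)NO)cc1`: 12300 nM
- compound 2 `Cc1ccc(-c2nc(CNc3ccc(C(=O)NO)cc3)n(-c3ccccc3)n2)cc1`: > 20000 nM

For compound 2, the entry > 20000 nM is a limit of the assay and not a number. Of the two compounds, only compound 1 has a measured number. Compound 3 `COc1ccc(-c2nc(CNc3ccc(C(=O)NO)cc3)n(-c3ccccc3)n2)cc1` has not yet been measured. It differs from compound 2 in one place, with methoxy in place of methyl on an aromatic carbon, para to a large group (methoxy in place of methyl on an aromatic carbon). The 4-methylphenyl of compound 2 thus becomes the 4-methoxyphenyl of compound 3. Within the data shown here, no pair of measured compounds shows this change. In this assay, the expected result is no step beyond the usual scatter, with neither direction favoured. In numbers, the expected step is a number no higher from compound 2 to compound 3 (the limit leaves the size open). The estimate for compound 3 is 20000 nM, with an expected range of 10000 nM to 40000 nM.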

Compound 3, half-maximal inhibitory concentration: > 20000 nM
Compound 3 gave a limit, no number; the forecaster's own chance of this, stated with the estimate: 60%; the middle value lies on the limit itself.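

Compound 2 and compound 3 both give a limit rather than a number, so no step can be read between them: the limit of > 20000 nM in this assay, at which 2 of the 3 values shown sit.

The compounds shown leave open whether the 4-methylphenyl and the 4-methoxyphenyl differ at all in their effect on these cells.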